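From compound 2 to compound 3: a swap on the shared core

A few compounds are considered here, and "the series" means these few. Any claim that something is new, unique, unknown or untested is made for them only; others in the source may bear on it.

Within the data shown here, compound 1 (`Cc1ccc(-c2cc(C(=O)Nc3cccnc3)c3cc(F)ccc3n2)cc1`) gives 50000 nM in an ADME assay on MRC5 cells (Homo sapiens) for antiproliferative activity, read by fluorescence and resazurin assay, with a stated time of 68 h (a higher number here means that more compound is needed for the effect, a lower number that less compound is needed), and provides the only numeric reading so far. Compound 2 (`Cc1cc(Nc2cc(C(=O)NCCN3CCCC3)c3cc(F)ccc3n2)on1`) reads > 50000 nM in this assay and that value is a limit of the assay, not a number. Compound 2 therefore stands at the limit of > 50000 nM in this assay, at which 1 of the 2 values shown sits, and has no exact value to build on.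

Compound 3 (`CN(C)c1ccc(-c2cc(C(=O)NCCN3CCCC3)c3cc(F)ccc3n2)cc1`) carries 4-(dimethylamino)phenyl in place of (3-methyl-1,2-oxazol-5-yl)amino on an aromatic carbon, next to the ring nitrogen (4-(dimethylamino)phenyl in place of (3-methyl-1,2-oxazol-5-yl)amino on an aromatic carbon), and the rest of compound 2 stays unchanged. Among the measured compounds shown here, no measured step shows what such an exchange does in this assay and any forecast here remains loose. A modest shift towards less compound needed is expected, with an at least 2.5-fold lower number from compound 2 to compound 3 (0.39 log units; beyond the scatter) as the estimated step, and a reading that again falls at the limit of the assay remains quite possible. Compound 3 is estimated at 20000 nM (range 6000 nM to 50000 nM) in this assay until the measurement is available.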

Compound 3, half-maximal effective concentration: 10000 nM
Estimate against measurement, compound 3: 2.0-fold (0.30 log units) above; the measured number falls inside the stated range.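

In this assay, among these compounds, 4-(dimethylamino)phenyl in place of (3-methyl-1,2-oxazol-5-yl)amino gives an at least 5.0-fold lower number from compound 2 to compound 3 (0.69 log units; beyond the scatter), the first readable step and one beyond the scatter. It shows that, with the rest of compound 2 unchanged, the group on this aromatic carbon next to the ring nitrogen can move the reading away from the top of the measured range. Its full size stays unknown, since compound 2 gives no exact starting value and one end of the step is a limit of the assay, not a number: the limit of > 50000 nM in this assay, at which 1 of the 3 values shown sits.

Among the compounds shown here, this single exchange replaces a five-membered aromatic ring with 2 hetero atoms and its amino link by a six-membered aromatic ring of carbon only that carries a dimethylamino group, so the share of each of these changes in the shift remains open. An unsubstituted phenyl at this position would separate the ring from the dimethylamino group, and a carboxylic acid or a morpholine in place of that dimethylamino group would show how far the reading depends on this substituent.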